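A few compounds are considered here, and "the series" means these few. Any claim that something is new, unique, unknown or untested is made for them only; others in the source may bear on it.

Two compounds of the series carry numbers in a functional assay on SGC-7901 cells (Homo sapiens) for antiproliferative activity, read by MTT assay, with a stated time of 48 h; a higher number here means a weaker inhibitor, a lower number a stronger inhibitor. Compound 1 `O=C(/C=C/c1ccc(Cl)cc1)/C=C/c1ccc(Oc2cc(=O)oc3ccccc23)cc1` gives 48300 nM in this assay. Compound 2 `COc1cc(OC)c2c(=O)c(OCCCCOc3ccc(/C=C/C(=O)/C=C/c4scnc4C)cc3)c(-c3cc(OC)c(OC)c(OC)c3)oc2c1` gives 42000 nM in this assay. The gap between the two lies within the scatter, so compound 2 stands level with compound 1 on this measure, and neither can be called the stronger inhibitor. For the measured compounds named here, the two structures differ in many places at once, so no single step between them can be read from these numbers.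

Compound 3 `COc1cc(OC)c2c(=O)c(OCCCCOc3ccc(/C=C/C(=O)/C=C/c4ccccn4)cc3)c(-c3cc(OC)c(OC)c(OC)c3)oc2c1` is the next member to be measured in this assay. It is built from compound 2 by one change: pyridin-2-yl in place of 4-methyl-1,3-thiazol-5-yl on a double-bonded chain carbon bound to a double-bonded chain carbon. Going by the values given here, nothing among the measured compounds bears on a swap of one aromatic ring for another at this place, so no direction can be drawn from the data. The expected step in this assay is a 1.1-fold lower number from compound 2 to compound 3 (0.02 log units; within the scatter), nothing beyond the scatter. For compound 3 the estimated value in this assay is 40000 nM, with a range from 15000 nM to 100000 nM.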

Compound 3, half-maximal inhibitory concentration: 2410 nM
The estimate for compound 3 lay 17-fold (1.22 log units) above the measured number; the whole stated range lies above it.
By their numbers in this assay, from the lowest: compound 3; then compounds 2 and 1 (each within the scatter of the next).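

Pyridin-2-yl in place of 4-methyl-1,3-thiazol-5-yl on a double-bonded chain carbon bound to a double-bonded chain carbon gives a 17-fold lower number from compound 2 to compound 3 (1.24 log units; beyond the scatter) in this assay, so this place in the series is sensitive to the identity of the aromatic ring it carries. Compounds 1 and 2 could not show this, as they differ in many places at once and stand within the scatter of each other. The change replaces a five-membered aromatic ring with two hetero atoms by a six-membered one with one, and it also removes the sulfur and the methyl group, so a single step cannot say which of these differences matters, and no measurement on hand accounts for the step.

On these data alone, whether an unsubstituted phenyl ring, a pyridin-3-yl or pyridin-4-yl group, or a thiazole ring without the methyl group would read like compound 3 or like compound 2 remains open. Also open, as far as these compounds go, is whether the step holds when the rest of the molecule changes, for example with a longer chain.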